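The source may hold more compounds than are shown below. What is called first, only, known or untested is meant among the compounds shown, and "the series" means these compounds.

Working notes on the sulfonamide series.

Compound 3 `O=C(NCc1ccccc1)c1ccc(S(=O)(=O)Nc2nccs2)cc1` stands at the weak end of the three numbers in hand: in an assay on cells for inhibition of sodium channel protein type 3 subunit alpha (Homo sapiens), read by electrophysiology (a lower number here means a stronger inhibitor, a higher number a weaker inhibitor), compound 3 gives 4450 nM, the highest of the set. Compound 1 `O=C(NCc1ccc(C(F)(F)F)cc1)c1ccc(S(=O)(=O)Nc2nccs2)cc1` gives 147 nM in this assay, and compound 2 `O=S(=O)(Nc1nccs1)c1ccc(-c2nnc(Cc3ccc(C(F)(F)F)cc3)[nH]2)cc1` gives 124 nM; both lie well below compound 3.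

The change to compound 4 `O=C(NCc1ccc(OC(F)(F)F)cc1)c1ccc(S(=O)(=O)Nc2nccs2)cc1` is trifluoromethoxy in place of hydrogen on an aromatic carbon. Within the data shown here, the one measured step that bears on this place is a 30-fold higher number from compound 1 to compound 3 (1.48 log units; beyond the scatter), where removing the trifluoromethyl from this aromatic carbon weakened inhibition sharply. Compound 4 puts a group of comparable make-up back at the same position, so the reverse direction is expected: a large fall in the number, possibly close in size to that step, though a group of five heavy atoms with an oxygen is not the same substituent and the match need not be exact. Compound 4 is therefore estimated at 200 nM in this assay, with a range of 60 nM to 900 nM, which means an expected step of a 22-fold lower number from compound 3 to compound 4 (1.35 log units; beyond the scatter).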

Compound 4, half-maximal inhibitory concentration: 197 nM
Beside the measured number, compound 4's estimate is 1.0-fold (0.01 log units) above it, within the range that was stated.
By their numbers in this assay, from the lowest: compounds 2, 1 and 4 (each within the scatter of the next); then compound 3.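

Trifluoromethoxy on an aromatic carbon para to a large group gives, in this assay, a 23-fold lower number from compound 3 to compound 4 (1.35 log units; beyond the scatter), so a large step at this position is not confined to trifluoromethyl. The direct exchange of trifluoromethyl for trifluoromethoxy gives a 1.3-fold higher number from compound 1 to compound 4 (0.13 log units; within the scatter), so the two groups cannot be told apart at this position in this series. No measurement is available that accounts for this shared behaviour.

The compounds shown cover only hydrogen, trifluoromethyl and trifluoromethoxy at this position, so it remains open whether a single fluorine, a methyl, a methoxy or an amine would give a number near those of the two fluorinated groups or near that of hydrogen. From the compounds shown here alone, it also remains open whether trifluoromethoxy can replace trifluoromethyl on the core of compound 2 with the same outcome.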